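A few compounds are considered here, and "the series" means these few. Any claim that something is new, unique, unknown or untested is made for them only; others in the source may bear on it.

Measured so far:
compound 1 `Cc1ccc(-n2cc(-c3ccccc3NS(=O)(=O)c3c[nH]c(=O)[nH]c3=O)nn2)cc1` — 6390 nM
compound 2 `O=c1[nH]cc(S(=O)(=O)Nc2ccccc2-c2cn(-c3ccc(Cl)cc3)nn2)c(=O)[nH]1` — 2700 nM
compound 3 `Cc1ccc(-n2cc(-c3cccc(NS(=O)(=O)c4c[nH]c(=O)[nH]c4=O)c3)nn2)cc1` — 9430 nM

All three values come from a functional assay on SGC-7901 cells (Homo sapiens) for antiproliferative activity, read by MTT assay, with a stated time of 24 h; a higher number here means a weaker inhibitor, a lower number a stronger inhibitor. Compound 3 has the highest of the three numbers; its gap to compound 1 lies within the scatter, its gap to compound 2 beyond it. Compound 4 `O=c1[nH]cc(S(=O)(=O)Nc2cccc(-c3cn(-c4cccc(Cl)c4)nn3)c2)c(=O)[nH]1` is not yet measured and differs from compound 3 by 3-chlorophenyl in place of 4-methylphenyl on an aromatic nitrogen. Within the data shown here, one measured step bears on this change: the chloro in place of methyl, a 2.4-fold lower number from compound 1 to compound 2 (0.37 log units; beyond the scatter), a modest lowering. Among the measured compounds shown here, the change here also moves the substituent to the 3-chlorophenyl pattern, for which no measured pair exists, so the expectation leans on that one step alone. Compound 4 is therefore expected to give a modestly lower number, a 2.1-fold lower number from compound 3 to compound 4 (0.32 log units; beyond the scatter), estimated at 4500 nM with a range of 2000 nM to 10000 nM.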

Compound 4, half-maximal inhibitory concentration: 3950 nM
Estimate against measurement, compound 4: 1.1-fold (0.06 log units) above; the range from low to high includes it.
By their numbers in this assay, from the lowest: compounds 2, 4, 1 and 3 (each within the scatter of the next, the first and the last beyond it).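

The change of 3-chlorophenyl for 4-methylphenyl on the aromatic nitrogen gives, in this assay, a 2.4-fold lower number from compound 3 to compound 4 (0.38 log units; beyond the scatter), so a chlorinated phenyl at this position also lowers the number on the core of compound 3, not only on the core of compound 1. This step changes both the substituent and its place on the phenyl ring, so it cannot assign the lowering to either alone. No measurement here explains the step. From the compounds shown here alone, the separate contributions of chlorine and its ring placement remain open on this core. Also open, going by these compounds, is how an amine or a carboxylic acid on this phenyl ring would compare.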